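Swapping Methoxy for Cyano on the Benzyl Ring

The compounds below may be only part of what the source reports. "The series", "measured", "known", "first", "only" and "open" are said of these compounds alone.

Compound 1 `CNC(=O)c1cc(C(=O)NC2CC2)cn(Cc2cccc(OC)c2)c1=O` was measured in a physicochemical assay for lipophilicity, at pH 7.4 (on this read-out higher numbers stand for higher lipophilicity and lower numbers for lower lipophilicity), and compound 1 gives 3. Compound 2 `CNC(=O)c1cccn(Cc2ccccc2)c1=O` gives 3, so compound 1 and compound 2 sit level at the digits shown and are together the lowest of the three numbers. Compound 3 `CNC(=O)c1cc(C(=O)NCCC(C)C)cn(Cc2ccccc2)c1=O` gives 4.8, the highest of the three, and the gap from compound 1 to compound 3 is beyond the scatter. Within the data shown here, the only measured step, a number 1.80 log units higher from compound 2 to compound 3 (beyond the scatter), concerns a different position and a different kind of group, so it does not inform the change studied here.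

Compound 4 `CNC(=O)c1cc(C(=O)NC2CC2)cn(Cc2cccc(C#N)c2)c1=O` differs from compound 1 in a single place: cyano in place of methoxy on an aromatic carbon. One small group leaves and another of the same size enters. Among the measured compounds shown here, no measured pair shows what this exchange does in this assay, so the step is expected to be small, a number 0.30 log units lower from compound 1 to compound 4 (within the scatter). For compound 4 the expected value is 2.7, within a range from 2.2 to 3.2.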

Compound 4, distribution coefficient: 2.6
For compound 4 the middle estimate is 0.10 log units above the measured one; the measured number falls inside the stated range.
By their numbers in this assay, from the lowest: compound 4; then compounds 1 and 2 (each within the scatter of the next); then compound 3.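

Cyano in place of methoxy on this aromatic carbon now has a measured size in this assay as a number 0.40 log units lower from compound 1 to compound 4 (beyond the scatter) and counts as a modest step. Among these compounds, the two groups match in heavy atoms and hydrogen-bond acceptors, yet the exchange still shifts the number beyond the usual scatter, so this place on the molecule can register a small swap, something the earlier compounds, whose only step lay at another place, could not show. Nothing measured here explains the direction of this step.

Where the number would fall with an amine, a carboxylic acid or a longer chain at this place remains open. Also open, on these data alone, is whether the same exchange gives a similar step when the isopentylcarbamoyl group of compound 3 is present.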